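The compounds below may be only part of what the source reports. "The series", "measured", "known", "first", "only" and "open" are said of these compounds alone.

Measured compounds:
compound 1, `COc1ccc(/C=N/N(Cc2ccccc2)Cc2ccccc2)cc1`, with 220 nM
compound 2, `COc1ccccc1/C=N/N(Cc1ccccc1)Cc1ccccc1`, with > 100000 nM
compound 3, `Clc1ccc(/C=N/N(Cc2ccccc2)Cc2ccccc2)cc1Cl`, with 2000 nM

In an assay on liver (Sus scrofa) for inhibition of glucose-6-phosphatase catalytic subunit 1 (Homo sapiens), using microsomes (on this read-out lower numbers stand for stronger inhibition and higher numbers for weaker inhibition), compound 1 gives 220 nM, the lowest of the two numbers recorded so far; compound 3 gives 2000 nM. Compound 2 gives > 100000 nM, which is a limit of the assay (the limit of > 100000 nM in this assay, at which 1 of the 3 values shown sits). Compound 4, `C(=N/N(Cc1ccccc1)Cc1ccccc1)\c1cccs1`, has not yet been measured; it differs from compound 1 by thiophen-2-yl in place of 4-methoxyphenyl on a carbon with a double bond to nitrogen. Two measured steps start from compound 1, both exchanging the ring on the carbon double-bonded to nitrogen: an at least 450-fold higher number from compound 1 to compound 2 (2.65 log units; beyond the scatter), and a 9.1-fold higher number from compound 1 to compound 3 (0.96 log units; beyond the scatter). Each departure from the 4-methoxyphenyl weakened inhibition, one of them beyond the limit of the assay. The thiophen-2-yl exchange likewise removes the 4-methoxyphenyl, so a weakening of moderate size is expected, a 6.8-fold higher number from compound 1 to compound 4 (0.83 log units; beyond the scatter). Compound 4 is accordingly estimated at 1500 nM, within a range from 300 nM to 8000 nM.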

Compound 4, half-maximal inhibitory concentration: 1500 nM
For compound 4 middle estimate and measured number coincide at the digits printed; the measured number falls inside the stated range.
By their numbers in this assay, from the lowest: compound 1; then compounds 4 and 3 (each within the scatter of the next). At a limit, above all of these: compound 2.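

In this assay, a five-membered ring carrying sulfur on the carbon with a double bond to nitrogen does not match the 4-methoxyphenyl, giving a 6.8-fold higher number from compound 1 to compound 4 (0.83 log units; beyond the scatter), yet it stays level with the 3,4-dichlorophenyl, at a 1.3-fold lower number from compound 3 to compound 4 (0.12 log units; within the scatter). Two rings as unlike as thiophen-2-yl and 3,4-dichlorophenyl therefore cannot be told apart here, while the 2-methoxyphenyl remains far from both, with an at least 66-fold lower number from compound 2 to compound 4 (1.82 log units; beyond the scatter). Compound 2 carries a limit, not a number: the limit of > 100000 nM in this assay, at which 1 of the 4 values shown sits.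

The compounds shown leave open whether the low number of compound 1 belongs to the methoxy group or to the six-membered ring that carries it, and how an unsubstituted phenyl or a ring bearing an amine would compare. They also leave open how furan-2-yl would compare with thiophen-2-yl at this position.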